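The compounds below may be only part of what the source reports. "The series", "measured", "known", "first", "only" and "open" are said of these compounds alone.

Working notes on the series.

Of the compounds shown here, two have so far been measured in a functional assay on MCF7 cells (Homo sapiens) for antiproliferative activity, read by sulforhodamine B assay, with a stated time of 72 h; a lower number here means a stronger inhibitor, a higher number a weaker inhibitor. Compound 1, `Clc1ccc(C(/C=C/c2ccccc2)=N\Nc2nncc3ccccc23)cc1`, gives 3.6 nM in this assay. Compound 2, `NC(=S)NNc1nncc2ccccc12`, gives 36 nM in this assay, the higher of the two numbers; the gap between compound 1 and compound 2 lies beyond the scatter. Within the data shown here, no single-change step between measured compounds is available, so these two values can only be compared as they stand.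

The next compound, compound 3, `S=C(NNc1nncc2ccccc12)Nc1ccccc1`, differs from compound 2 in one place: phenyl in place of hydrogen on an amide-type nitrogen. The amide-type nitrogen that carries the new phenyl is the one bonded to the thiocarbonyl carbon.

For compound 3 in this assay, a modest step toward a lower number is expected, of the size a 2.4-fold lower number from compound 2 to compound 3 (0.38 log units; beyond the scatter), since the aromatic-rich compound 1 stands at 3.6 nM. Compound 3 is estimated at 15 nM, within 4 nM to 60 nM.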

Compound 3, half-maximal inhibitory concentration: 47 nM
The estimate for compound 3 lay 3.1-fold (0.50 log units) below the measured number; measured number inside the range.
By their numbers in this assay, from the lowest: compound 1; then compounds 2 and 3 (each within the scatter of the next).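

In this assay the exchange gives a 1.3-fold higher number from compound 2 to compound 3 (0.12 log units; within the scatter) for phenyl in place of hydrogen on an amide-type nitrogen whose other neighbour is the thiocarbonyl carbon. This nitrogen therefore takes a six-membered aromatic ring of carbon only with no difference that can be read in this assay, something the two earlier compounds, which differ in more than one place, could not show. No measurement is at hand that explains this result.

From the compounds shown here alone, it remains open whether a methyl group, a longer alkyl chain or a benzyl group on this nitrogen would also stay within the scatter of compound 2. Going by these compounds, it is equally open whether a chlorine or a carboxylic acid on the new phenyl ring would move the number beyond the scatter.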